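The source may hold more compounds than are shown below. What is called first, only, known or untested is meant among the compounds shown, and "the series" means these compounds.

Working notes on the series. In a functional assay on A549 cells (Homo sapiens) for cytotoxicity, read by sulforhodamine B assay, with a stated time of 2 days, tested at 100 uM (a lower number here means less inhibition, a higher number more inhibition at the concentration tested (going by the name of the read-out)), compound 1 `O=C(Nn1c(-c2cccc([N+](=O)[O-])c2)nc2c(-c3ccc(Cl)cc3)n[nH]c2c1=O)c1ccccc1` gives 88.6%, while compound 2 `O=C(Nn1c(-c2cccc([N+](=O)[O-])c2)nc2c(-c3ccco3)n[nH]c2c1=O)c1ccccc1` gives 18.7%, the lowest of the two numbers; its nearest neighbour is compound 1, and a number 69.9 percentage points lower from compound 1 to compound 2 (beyond the scatter). Compound 3 `O=C(Nn1c(-c2cccc([N+](=O)[O-])c2)nc2c(CCc3ccccc3)n[nH]c2c1=O)c1ccccc1` is not yet measured; it differs from compound 2 by phenethyl in place of furan-2-yl on an aromatic carbon. For the measured compounds named here, the only measured step at this position is the large drop from compound 1 to compound 2, which shows the position matters but does not cover an aryl-to-phenethyl change, so the direction is uncertain. Compound 3 is expected to return part of the way, at 45% with a range of 12% to 80%, an estimated step of a number 26.3 percentage points higher from compound 2 to compound 3 (beyond the scatter).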

Compound 3, a percentage reported as inhibition, at one concentration (the size of the read-out at that concentration, not a potency): 73.9%
Estimate against measurement, compound 3: 28.9 percentage points below; low and high end bracket the measured number.
By their numbers in this assay, from the lowest: compound 2; then compound 3; then compound 1.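

Phenethyl in place of furan-2-yl gives a number 55.2 percentage points higher from compound 2 to compound 3 (beyond the scatter) and so restores much of the reading, which shows that an aromatic ring bonded straight to this carbon is not needed for a high number. Phenethyl in place of 4-chlorophenyl gives a number 14.7 percentage points lower from compound 1 to compound 3 (beyond the scatter) and so costs far less than furan-2-yl does. No measurement available here accounts for these steps. Still open, on these data alone, is whether a benzyl group, a longer chain or an amine at this position would hold the reading, and whether unsubstituted phenyl would match 4-chlorophenyl.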